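The source may hold more compounds than are shown below. What is called first, only, known or untested is meant among the compounds shown, and "the series" means these compounds.

In a functional assay (aorta) with Rattus norvegicus as the target (on this read-out lower numbers stand for an effect already at smaller amounts and higher numbers for an effect only at larger amounts of compound), three compounds sharing one core have been measured. Compound 1 (`COc1ccc(-c2nc(CN(C)C)sc2-c2ccc(OC)cc2)cc1`) gives 8.4 uM, compound 2 (`COc1ccc(-c2nc(CNC(C)=O)sc2-c2ccc(OC)cc2)cc1`) gives 8.1 uM, and compound 3 (`COc1ccc(-c2nc(CNC(=O)CSc3ccccc3)sc2-c2ccc(OC)cc2)cc1`) gives 4.2 uM. Compound 3 does not stand apart from the other two: a 2.0-fold lower number from compound 1 to compound 3 (0.30 log units; within the scatter) and a 1.9-fold lower number from compound 2 to compound 3 (0.29 log units; within the scatter) both remain within the scatter.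

Compound 4 (`COc1ccc(-c2nc(CNC(=O)C3=NNC(=O)CC3)sc2-c2ccc(OC)cc2)cc1`) differs from compound 3 at a single place, on a carbonyl carbon: a group of 7 heavy atoms (4 carbon, 2 nitrogen, 1 oxygen; one six-membered non-aromatic ring with 2 hetero atoms) in place of a group of 8 heavy atoms (7 carbon, 1 sulfur; one six-membered aromatic ring of carbon only), on a carbonyl carbon. The (phenylsulfanyl)methyl group leaves, and a six-membered non-aromatic ring with 2 hetero atoms enters. For the measured compounds named here, no measured compound carries this ring, so the data do not test it directly. The nearest evidence comes from the other changes made around this carbonyl. Placing phenylsulfanyl in place of hydrogen on a saturated chain carbon bound to a carbonyl carbon gave a 1.9-fold lower number from compound 2 to compound 3 (0.29 log units; within the scatter), and replacing dimethylamino with acetamido gave a 1.0-fold lower number from compound 1 to compound 2 (0.02 log units; within the scatter). Neither step left the scatter.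

On that basis, no step beyond the scatter is expected in this assay, and no firm direction can be assigned. The estimated step is a 1.7-fold higher number from compound 3 to compound 4 (0.22 log units; within the scatter), a slight lean toward compound 2 at 8.1 uM. Compound 4 is expected at 7 uM, within an estimated range of 2.5 uM to 20 uM.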

Compound 4, concentration for half-maximal effect: 7.3 uM
Compound 4: middle estimate off by 1.0-fold (0.02 log units), on the low side, and the stated range covers the measured number.
By their numbers in this assay, from the lowest: compounds 3, 4, 2 and 1 (each within the scatter of the next).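

In this assay, the (phenylsulfanyl)methyl group on the carbonyl carbon gave way to a six-membered non-aromatic ring with 2 hetero atoms, which gave a 1.7-fold higher number from compound 3 to compound 4 (0.24 log units; within the scatter) and thus no readable change. Set against the small acetamido group, the same ring gave a 1.1-fold lower number from compound 2 to compound 4 (0.05 log units; within the scatter) and, against the dimethylamino group, it gave a 1.2-fold lower number from compound 1 to compound 4 (0.06 log units; within the scatter), so this position, until now seen only with open-chain groups, also accepts a non-aromatic ring that brings a hydrogen-bond donor without the read-out leaving the scatter in any of the comparisons. No information is at hand that would explain this flat response.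

With all four compounds lying within the scatter of one another, the shown set does not reveal any group on this carbonyl carbon that moves the read-out, and it remains open whether a carboxylic acid, a primary amine or a longer chain ending in a phenyl ring would do so. Going by these compounds, the two methoxy groups are also the same throughout, so whether a hydroxy group or a fluorine atom in their place would matter stays unknown.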